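The compounds below may be only part of what the source reports. "The series", "measured", "known", "first", "only" and "open" are said of these compounds alone.

Measured compounds:
compound 1 `c1ccc2c(c1)CCC2NC1CCN(CCCc2c[nH]c3ccc(-n4cnnc4)cc23)CC1` gives 8.9 nM
compound 2 `COC[C@H](NC1CCN(CCCc2c[nH]c3ccc(Cn4cncn4)cc23)CC1)c1ccc(F)cc1` gives 5 nM
compound 3 `CN(Cc1ccc(S(C)(=O)=O)cc1)C1CCN(CCCc2c[nH]c3ccc(-n4cnnc4)cc23)CC1` gives 18 nM

All three numbers come from an assay on CHO cells for displacement of a labelled ligand from 5-hydroxytryptamine receptor 1D (Homo sapiens); on this read-out higher numbers stand for weaker inhibition and lower numbers for stronger inhibition. Among them compound 1 stands second highest. Compound 2 lies close to it, within the scatter of this assay, so the two cannot be told apart. Compound 3 gives a higher number than compound 1, and that gap lies beyond the scatter. Compound 4 `CC(=O)Nc1ccc(CNC2CCN(CCCc3c[nH]c4ccc(-n5cnnc5)cc34)CC2)cc1` has not yet been measured. It is built from compound 1 by one change: 4-acetamidobenzyl in place of 2,3-dihydro-1H-inden-1-yl on an amine nitrogen. Among the compounds with values here, no step between two measured compounds covers this exact exchange, so there is no measured guide for it. The shared core and the piperidine-bearing chain are kept, and compound 3, which also carries a substituted benzyl group on that nitrogen, still sits in the same range as compound 1. On that footing the step of a 1.3-fold higher number from compound 1 to compound 4 (0.13 log units; within the scatter) is expected to be small, at most a mild rise in the number, within the scatter. Compound 4 is therefore estimated at 12 nM, with a range from 4 nM to 40 nM.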

Compound 4, half-maximal inhibitory concentration: 3 nM
The estimate for compound 4 lay 4.0-fold (0.60 log units) above the measured number; measured number outside the range, below it.
By their numbers in this assay, from the lowest: compounds 4, 2 and 1 (each within the scatter of the next, the first and the last beyond it); then compound 3.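

Exchanging 2,3-dihydro-1H-inden-1-yl for 4-acetamidobenzyl on this amine nitrogen gives a 3.0-fold lower number from compound 1 to compound 4 (0.47 log units; beyond the scatter) in this assay and carries the number beyond the scatter. The position therefore does not depend on the five-membered carbon ring of compound 1, and it accepts a larger group with one hydrogen-bond donor and one acceptor where the departing group has neither. Nothing available explains why the number falls with this change.

The compounds shown leave open how much of the step belongs to the acetamido group and how much to the benzyl group itself, which an unsubstituted benzyl group or an aminobenzyl group on the same nitrogen would help to separate. They also leave open whether a methyl group on this nitrogen would alter the result.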